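The source may report more compounds than this note shows. Statements on the series, on what has been measured and on what is new or still open speak of the compounds shown alone.

In a functional assay on KB 3-1 cells (Homo sapiens) for cytotoxicity, read by MTT assay, with a stated time of 68 h (on this read-out higher numbers stand for weaker inhibition and lower numbers for stronger inhibition), compound 1 (`O=C(Nc1cccc(-c2cccc(F)c2)c1)C(Cl)Cl`) gives > 50000 nM, a limit of the assay and not a number. Compound 2 (`Cc1ccc(-c2cccc(NC(=O)C(Cl)Cl)c2)cc1`) gives > 50000 nM, which is also only a limit, so compound 2 stands without a number of its own. Within the data shown here, no measured step between compounds exists, and the only ground for sizing a change is the limit of > 50000 nM in this assay, at which 2 of the 2 values shown sit.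

Compound 3 (`COC(=O)c1ccc(-c2cccc(NC(=O)C(Cl)Cl)c2)cc1`) has methoxycarbonyl in place of methyl on an aromatic carbon, para to a large group: methoxycarbonyl in place of methyl on an aromatic carbon. No shift beyond the scatter is expected in this assay, in either direction. The estimated a number no higher from compound 2 to compound 3 (the limit leaves the size open) is therefore expected to be no real change, and a report of a limit again is the likeliest result. For compound 3 the expected half-maximal inhibitory concentration, should a number be reported, is 50000 nM, with an estimated range of 20000 nM to 100000 nM.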

Compound 3, half-maximal inhibitory concentration: > 50000 nM
Compound 3 gave a limit, no number; the forecaster's own chance of this, stated with the estimate: 75%; the middle value sits exactly at the limit.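

Among these compounds, compound 2 and compound 3 both give only a limit in this assay, so the step between them cannot be read and no new step follows. The compounds shown leave open whether any change on the shared core would yield an actual number: the limit of > 50000 nM in this assay, at which 3 of the 3 values shown sit.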